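The source may report more compounds than this note shows. Statements on the series, on what has been measured and on what is new or still open speak of the compounds shown alone.

Compound 2 `Cn1cnnc1SCC(=O)Nc1ccc(-c2nc(-c3ccccc3)c(-c3ccccc3)n2C)cc1` gives 88% in a functional assay on HT-29 cells (Homo sapiens) for cytotoxicity, read by MTT assay, with a stated time of 24 h, tested at 80 ug/mL (a higher number here means a stronger effect of the compound at the concentration tested, a lower number a weaker effect), the highest of the three numbers shown: compound 1 `Cn1c(-c2ccc(NC(=O)CCl)cc2)nc(-c2ccccc2)c1-c1ccccc1` gives 76.1%, and compound 3 `CN(C)/C=C/N1CCN(CC(=O)Nc2ccc(-c3nc(-c4ccccc4)c(-c4ccccc4)n3C)cc2)CC1` gives 45.4%. Compound 4 `Cn1c(-c2ccc(NC(=O)CN3CCN(c4ccccc4)CC3)cc2)nc(-c2ccccc2)c1-c1ccccc1` differs from compound 2 by 4-phenylpiperazin-1-yl in place of (4-methyl-4H-1,2,4-triazol-3-yl)sulfanyl on a saturated chain carbon bound to a carbonyl carbon. Among the compounds with values here, no measured step exchanges these two groups directly. The nearest guides are the two steps that bring in a piperazin-1-yl group, a number 42.6 percentage points lower from compound 2 to compound 3 (beyond the scatter) and a number 30.7 percentage points lower from compound 1 to compound 3 (beyond the scatter), both large falls. Compound 3 carries a piperazin-1-yl group too, though with 2-(dimethylamino)ethenyl rather than phenyl, and gives 45.4%. On that basis a fall beyond the scatter is expected for compound 4, namely a number 33 percentage points lower from compound 2 to compound 4 (beyond the scatter). Compound 4 is estimated at 55% in this assay, between 30% and 80%.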

Compound 4, a percentage reported as activity, at one concentration (the size of the read-out at that concentration, not a potency): 63.7%
The estimate for compound 4 lay 8.7 percentage points below the measured number; the range from low to high includes it.
By their numbers in this assay, from the lowest: compound 3; then compound 4; then compound 1; then compound 2.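

In this assay the group on the amine nitrogen in a ring changes the result, with phenyl in place of 2-(dimethylamino)ethenyl giving (a number 18.3 percentage points higher from compound 3 to compound 4 (beyond the scatter)). A piperazin-1-yl group on the saturated chain carbon bound to a carbonyl carbon therefore does not alone set the number. Even so, 4-phenylpiperazin-1-yl stays short of both (4-methyl-4H-1,2,4-triazol-3-yl)sulfanyl (a number 24.3 percentage points lower from compound 2 to compound 4 (beyond the scatter)) and chloro (a number 12.4 percentage points lower from compound 1 to compound 4 (beyond the scatter)). Nothing available explains these differences. Going by these compounds, whether a benzyl group on that amine nitrogen, or a morpholin-4-yl group on the chain carbon, would compare with phenyl stays open.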